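Compound 2 to compound 4: cyclohexyl on the nitrogen

This account rests on a few compounds, and the source may have more. Where it says the series, first, only, none or still open, it means among the compounds named here.

In a physicochemical assay for solubility, with a stated time of 24 h, tested at 30 mg/mL (a lower number here means a less soluble compound, a higher number a more soluble compound), compound 2 `C[C@@H](Nc1c(NCCCCCC(=O)NO)c(=O)c1=O)c1ccccc1` gives 39000000 nM, the second highest of three numbers. Compound 1 `O=C(CCCCCNc1c(Nc2ccccc2)c(=O)c1=O)NO` gives 2200000 nM and compound 3 `Cc1cccc([C@@H](C)Nc2c(NCCCCCC(=O)NO)c(=O)c2=O)c1` gives 82000000 nM. Compound 4 `O=C(CCCCCNc1c(NC2CCCCC2)c(=O)c1=O)NO` puts cyclohexyl in place of 1-phenylethyl on a nitrogen on an aromatic ring. The most relevant measured change is at that same place, an 18-fold higher number from compound 1 to compound 2 (1.25 log units; beyond the scatter), which is large. The other, a 2.1-fold higher number from compound 2 to compound 3 (0.32 log units; beyond the scatter), is modest and sits on an aromatic carbon, so it bears less. Among the measured compounds shown here, no measured compound carries cyclohexyl. The expected change is a 2.6-fold lower number from compound 2 to compound 4 (0.41 log units; beyond the scatter), a lower number in this assay and a smaller step than the large one. Compound 4 is estimated at 15000000 nM, with an expected range of 4000000 nM to 50000000 nM.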

Compound 4, solubility: 8700000 nM
Estimate against measurement, compound 4: 1.7-fold (0.24 log units) above; the measured number falls inside the stated range.
By their numbers in this assay, from the lowest: compound 1; then compound 4; then compound 2; then compound 3.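

In this assay, a non-aromatic ring on this nitrogen gives a number on neither extreme of the earlier range: a 4.5-fold lower number from compound 2 to compound 4 (0.65 log units; beyond the scatter), yet a 4.0-fold higher number from compound 1 to compound 4 (0.60 log units; beyond the scatter). The higher number relative to compound 1 therefore does not need an aromatic ring at this position, although cyclohexyl does not match 1-phenylethyl here. Nothing available explains either step. Open, as far as these compounds go, is whether the drop from compound 2 follows the aromatic ring or the branched carbon, which benzyl or 1-cyclohexylethyl on this nitrogen could separate. From the compounds shown here alone, an amine or a carboxylic acid on the cyclohexyl ring also remains open.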